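This account rests on a few compounds, and the source may have more. Where it says the series, first, only, none or still open, it means among the compounds named here.

Of the compounds shown here, two sharing one core have been measured in a functional assay (Homo sapiens) for antiproliferative activity, read by resazurin assay, with a stated time of 48 h, tested at 10 uM; a higher number here means a stronger effect of the compound at the concentration tested, a lower number a weaker effect. Compound 1 `COc1cc(OC)c2c(=O)cc(-c3ccc(OCC(O)CN4CCCC4)cc3)oc2c1` gives 37%, and compound 2 `COc1cc(OC)c2c(=O)cc(-c3ccc(OCC(O)CO)cc3)oc2c1` gives 11%. Compound 2 thus stands lowest of the two values, separated from compound 1 by the step of a number 26 percentage points lower from compound 1 to compound 2 (beyond the scatter). The unmeasured compound 3 `COc1cc(OC)c2c(=O)cc(-c3ccc(-c4ccc(F)nc4)cc3)oc2c1` differs from compound 2 in one place: 6-fluoropyridin-3-yl in place of 2,3-dihydroxypropoxy on an aromatic carbon. Among the compounds with values here, no measured step covers such an exchange. Within the data shown here, the one step known, a number 26 percentage points lower from compound 1 to compound 2 (beyond the scatter), swaps a single group on the chain that compound 2 carries, and that whole chain now leaves, so it gives no direct guide; it does show that what sits at this place can shift the number by a modest amount. For compound 3 the expected step of a number 14 percentage points higher from compound 2 to compound 3 (beyond the scatter) is therefore uncertain and is taken as small. The estimate for compound 3 in this assay is 25%, within a range from 5% to 55%.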

Compound 3, a percentage reported as inhibition, at one concentration (the size of the read-out at that concentration, not a potency): 6%
For compound 3 the middle estimate is 19 percentage points above the measured one, and the stated range covers the measured number.
By their numbers in this assay, from the lowest: compounds 3 and 2 (each within the scatter of the next); then compound 1.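

In this assay, exchanging the whole 2,3-dihydroxypropoxy chain for 6-fluoropyridin-3-yl gives a number 5 percentage points lower from compound 2 to compound 3 (within the scatter) and so does not separate these two very different groups, one an open chain with hydrogen-bond donors and the other an aromatic ring without any. The same ring measured against the 2-hydroxy-3-(pyrrolidin-1-yl)propoxy chain gives a number 31 percentage points lower from compound 1 to compound 3 (beyond the scatter) and so, among the three groups seen on this aromatic carbon, only the chain ending in pyrrolidine stands apart from the other two. Nothing available explains this result.

Still open, going by these compounds, is whether another amine at the end of the same chain, such as piperidine or morpholine, would match the pyrrolidine. Also open, on these data alone, is whether an aminomethyl group on the pyridine ring would change the reading for the ring.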